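This account rests on a few compounds, and the source may have more. Where it says the series, first, only, none or still open, it means among the compounds named here.

Compound 1, `CCCCCCCNc1cc(-c2ccccc2)c(-c2ccccc2)nn1`: 55000 nM
Compound 2, `CCCCCCCCOc1cc(-c2ccccc2)c(-c2ccccc2)nn1`: 104000 nM

Both compounds share one core and differ only in the chain on the aromatic carbon. In an assay on microsomes from liver for inhibition of sterol O-acyltransferase 1 (Rattus norvegicus) (a higher number here means a weaker inhibitor, a lower number a stronger inhibitor), compound 2 gives the larger of the two numbers, but the step of a 1.9-fold higher number from compound 1 to compound 2 (0.28 log units; within the scatter) leaves the two compounds indistinguishable in this assay.

Compound 3, `CCCCCCS(=O)(=O)c1cc(-c2ccccc2)c(-c2ccccc2)nn1`, is the next member of the series. The change from compound 2 is hexylsulfonyl in place of octyloxy on an aromatic carbon. Among the compounds with values here, the only measured step, from compound 1 to compound 2, swapped one chain for another on the same carbon and stayed within the scatter; no step with a sulfonyl group has been measured, so the data offer no direct guide. Within the data shown here, with that single small step as the only precedent, a step of no more than the scatter is expected, a 1.0-fold lower number from compound 2 to compound 3 (0.02 log units; within the scatter), with wide uncertainty. Compound 3 is therefore estimated at 100000 nM, with a range from 25000 nM to 400000 nM.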

Compound 3, half-maximal inhibitory concentration: 60000 nM
Beside the measured number, compound 3's estimate is 1.7-fold (0.22 log units) above it, within the range that was stated.
By their numbers in this assay, from the lowest: compounds 1, 3 and 2 (each within the scatter of the next).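

At this aromatic carbon of the shared core, putting hexylsulfonyl in place of octyloxy gives a 1.7-fold lower number from compound 2 to compound 3 (0.24 log units; within the scatter) in this assay, and putting it in place of heptylamino gives a 1.1-fold higher number from compound 1 to compound 3 (0.04 log units; within the scatter) in the same assay. The position therefore accepts a sulfonyl-linked chain as well as the amino- and oxy-linked chains of the earlier pair, and this assay does not distinguish among the three compounds. Nothing available accounts for how closely these compounds agree.

The linking group and the chain length change together across these compounds, so their separate contributions remain unread. Also open, on these data alone, is whether a much shorter chain such as methyl, or a chain ending in a carboxylic acid or an amine, would move the number beyond the scatter.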